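The source may report more compounds than this note shows. Statements on the series, on what has been measured and on what is new or still open speak of the compounds shown alone.

Compound 1 `C#CCN(C)Cc1cn(-c2cc(NC(=S)NCC)ncn2)cn1`, compound 2 `C#CCN(CC)Cc1cn(-c2cc(NC(=S)NCC)ncn2)cn1` and compound 3 `C#CCN(CCCC)Cc1cn(-c2cc(NC(=S)NCC)ncn2)cn1` share one core and differ only in the alkyl group on the amine nitrogen. In an assay on isolated protein for inhibition of Amine oxidase [flavin-containing] A (Homo sapiens), read by fluorescence and Amplex Red, with a stated time of 15 min (on this read-out higher numbers stand for weaker inhibition and lower numbers for stronger inhibition), compound 1 gives only a limit, > 50000 nM. In this assay compound 2 likewise reaches only a limit, > 50000 nM. Compound 3 too stops at a limit in this assay, > 50000 nM. The steps a step that the two limits leave unreadable from compound 1 to compound 2, a step that the two limits leave unreadable from compound 1 to compound 3 and a step that the two limits leave unreadable from compound 2 to compound 3 carry no readable size, since all values sit at the limit of > 50000 nM in this assay, at which 3 of the 3 values shown sit. Compound 4 `C#CCN(Cc1ccccc1)Cc1cn(-c2cc(NC(=S)NCC)ncn2)cn1` differs from compound 2 by phenyl in place of methyl on a saturated chain carbon bound to an amine nitrogen. Going by the values given here, with no measured step readable, no direction of change beyond the limit is expected. For compound 4 the expected value in this assay is 60000 nM, in the range 20000 nM to 200000 nM. This corresponds to an expected step that the limit leaves unreadable from compound 2 to compound 4.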

Compound 4, half-maximal inhibitory concentration: > 50000 nM
Compound 4: no number, only a limit; the forecaster's own chance of this, stated with the estimate: 75%; the middle value does not contradict the limit.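

The steps from compound 1, compound 2 and compound 3 to compound 4 cannot be read, since each of these compounds gives only a limit: the limit of > 50000 nM in this assay, at which 4 of the 4 values shown sit.

The compounds shown leave open whether changing the group on the amine nitrogen alters inhibition in this assay at all.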